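Another Replacement of the Hydroxymethyl Group on the Shared Core

The compounds below may be only part of what the source reports. "The series", "measured", "known", "first", "only" and "open" are said of these compounds alone.

Compound 1 `Cc1c(-c2ccc(-c3ccccc3F)cc2)nc2ccc(F)cc2c1CO` is the only one of the three measured compounds that gives a number: in a functional assay on MOLM-13 cells (Homo sapiens) for antiproliferative activity (on this read-out lower numbers stand for stronger inhibition and higher numbers for weaker inhibition), compound 1 gives 700 nM. Compound 2 `Cc1c(-c2ccc(-c3ccccc3F)cc2)nc2ccc(F)cc2c1C(=O)C(F)(F)F` reaches only a limit in this assay, > 3000 nM. Compound 3 `Cc1c(-c2ccc(-c3ccccc3F)cc2)nc2ccc(F)cc2c1-c1noc(=O)[nH]1` likewise gives only a limit, > 3000 nM. Compound 4 `CCONC(=O)c1c(C)c(-c2ccc(-c3ccccc3F)cc2)nc2ccc(F)cc12` differs from compound 1 by ethoxycarbamoyl in place of hydroxymethyl on an aromatic carbon. The two measured steps both replace that same hydroxymethyl with something larger: an at least 4.2-fold higher number from compound 1 to compound 2 (0.63 log units; beyond the scatter) and an at least 4.2-fold higher number from compound 1 to compound 3 (0.63 log units; beyond the scatter), each ending at the limit of > 3000 nM in this assay, at which 2 of the 3 values shown sit. Since both of those replacements weakened inhibition, a weaker result is expected for compound 4 as well, a 4.3-fold higher number from compound 1 to compound 4 (0.63 log units; beyond the scatter). Compound 4 is therefore estimated at 3000 nM, with a range from 800 nM to 10000 nM, and this assay may once more report only a limit.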

Compound 4, half-maximal inhibitory concentration: 33 nM
Estimate against measurement, compound 4: 91-fold (1.96 log units) above, outside the stated range (below it).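

In this assay, the position opposite the ring nitrogen tolerates a larger group than hydroxymethyl: ethoxycarbamoyl gives a 21-fold lower number from compound 1 to compound 4 (1.33 log units; beyond the scatter), the first gain among these replacements. Heavy-atom count alone does not decide the outcome, as groups of equal count give an at least 90-fold lower number from compound 3 to compound 4 (1.95 log units; beyond the scatter) and an at least 90-fold lower number from compound 2 to compound 4 (1.95 log units; beyond the scatter). Both of these steps start from a limit, not a number: the limit of > 3000 nM in this assay, at which 2 of the 4 values shown sit.

The compounds shown do not tell which part of ethoxycarbamoyl carries the gain. On these data alone, how a carboxylic acid, a plain carboxamide or a longer alkoxy chain would read at this position stays open.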